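The source may report more compounds than this note shows. Statements on the series, on what has been measured and on what is new or still open speak of the compounds shown alone.

Measured so far:

- Compound 1, `CCOc1ccc(NC(=O)c2cccc(/C=C3\CC(=O)N(c4ccccc4)C3=O)c2)cc1`. In an ADME assay on NCM460 cells (Homo sapiens) for cytotoxicity, read by MTT assay, with a stated time of 72 h (a lower number here means a stronger inhibitor, a higher number a weaker inhibitor), compound 1 gives > 100000 nM, which is a limit of the assay and not a number.
- Compound 2, `COc1ccc(NC(=O)c2cccc(/C=C3\CC(=O)N(c4ccccc4)C3=O)c2)cc1`. In this assay compound 2 gives > 100000 nM, again only a limit.
- Compound 3, `Cc1ccc(NC(=O)c2cccc(/C=C3\CC(=O)N(c4ccccc4)C3=O)c2)cc1`. In this assay compound 3 gives > 100000 nM, also a limit.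

Compound 3 thus stands at the same limit as the other two measured compounds; no number separates them. The three steps among them, a step that the two limits leave unreadable from compound 1 to compound 2, a step that the two limits leave unreadable from compound 1 to compound 3 and a step that the two limits leave unreadable from compound 2 to compound 3, are all unreadable because of the limit of > 100000 nM in this assay, at which 3 of the 3 values shown sit. Changes on the aromatic ring that carries the amide-type nitrogen, from ethoxy to methoxy to methyl, have so far produced nothing that the assay could resolve.

Compound 4, `CSc1cccc(NC(=O)c2cccc(/C=C3\CC(=O)N(c4ccccc4)C3=O)c2)c1`, is not yet measured. It differs from compound 3 by 3-(methylsulfanyl)phenyl in place of 4-methylphenyl on an amide-type nitrogen. Among the compounds with values here, none of the measured steps gives a readable size, so there is no evidence that a change on this ring moves the value out of the limit. The expected step in this assay is a number no higher from compound 3 to compound 4 (the limit leaves the size open), which is none beyond the scatter. Compound 4 is therefore expected to give about 100000 nM, within 40000 nM to 300000 nM, most likely reported again only as a limit.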

Compound 4, half-maximal inhibitory concentration: > 100000 nM
Compound 4 was reported as a limit (the forecaster's own chance of this, stated with the estimate: 85%); the middle value sits exactly at the limit.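

Within the data shown here, compound 4 stands with compound 1, compound 2 and compound 3 at a limit of this assay, so no step among them can be read: the limit of > 100000 nM in this assay, at which 4 of the 4 values shown sit. The compounds shown leave open whether any group on the amide-type nitrogen would give a measurable number.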